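The source may hold more compounds than are shown below. What is called first, only, known or untested is meant among the compounds shown, and "the series" means these compounds.

Values so far in a physicochemical assay for acid dissociation, are these
Compound 1 `NS(=O)(=O)c1ccc(S(=O)(=O)CCO)c(F)c1` gives 9
Compound 2 `NS(=O)(=O)c1ccc(S(=O)(=O)CCCO)c(F)c1` gives 9.02
Compound 3 `COC(=O)c1cc(S(N)(=O)=O)ccc1S(=O)(=O)CCO` gives 9.2

Compound 2 at 9.02 lies within the scatter of both other compounds. Compound 4 `Nc1cc(S(N)(=O)=O)ccc1S(=O)(=O)CCCO` carries amino in place of fluoro on an aromatic carbon and has not been measured yet. For the measured compounds named here, two measured steps bear on this. Changing the chain gave a number 0.02 log units higher from compound 1 to compound 2 (within the scatter) and is only background, while replacing fluoro with methoxycarbonyl gave a number 0.20 log units higher from compound 1 to compound 3 (within the scatter) on the aromatic carbon in question. Going by the values given here, no measured step introduces amino, so the expectation is uncertain. A modest step to a higher number is expected, estimated as a number 0.38 log units higher from compound 2 to compound 4 (beyond the scatter) here. Compound 4 is expected near 9.4 with an estimated range of 9.1 to 9.8 in this assay when measured.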

Compound 4, acid dissociation constant: 9.15
Beside the measured number, compound 4's estimate is 0.25 log units above it, within the range that was stated.
By their numbers in this assay, from the lowest: compounds 1, 2, 4 and 3 (each within the scatter of the next).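

In this assay, amino in place of fluoro on an aromatic carbon, ortho to a group of 7 heavy atoms, gives a number 0.13 log units higher from compound 2 to compound 4 (within the scatter) and so adds a second replacement of fluoro at this position. Like methoxycarbonyl in a number 0.20 log units higher from compound 1 to compound 3 (within the scatter) before it, amino leaves the number within the scatter, so neither replacement shown here separates clearly from fluoro. Nothing available gives a reason for the size of this step. Going by these compounds, whether a carboxylic acid or a nitrile on this aromatic carbon would also stay within the scatter remains open, as does the outcome for a longer chain on the sulfonyl sulfur.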